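A few compounds are considered here, and "the series" means these few. Any claim that something is new, unique, unknown or untested is made for them only; others in the source may bear on it.

The measured compounds in a functional assay on FM3A cells (Mus musculus) for antiproliferative activity; a lower number here means a stronger inhibitor, a higher number a weaker inhibitor:

Compound 1, `COc1cc(C(=O)c2sc(-c3cccc([N+](=O)[O-])c3)cc2N)cc(OC)c1OC`, gives 17 nM.
Compound 2, `COc1cc(C(=O)c2sc(-c3ccsc3)cc2N)cc(OC)c1OC`, gives 3.7 nM.
Compound 3, `COc1cc(C(=O)c2sc(-c3ccc(-c4ccccc4)cc3)cc2N)cc(OC)c1OC`, returns only a limit of the assay, > 10000 nM.

Compound 2 holds the lowest of the two numbers reported; its nearest neighbour is compound 1, reached by a 4.6-fold lower number from compound 1 to compound 2 (0.66 log units; beyond the scatter), which the thiophen-3-yl compound passes beyond the scatter. Compound 3 is a limit and not a number, and the evidence the limit of > 10000 nM in this assay, at which 1 of the 3 values shown sits, marks where that value sits.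

Compound 4, `COc1cc(C(=O)c2sc(-c3ccc(Br)cc3)cc2N)cc(OC)c1OC`, is not yet measured. The change from compound 2 is 4-bromophenyl in place of thiophen-3-yl on an aromatic carbon.

Among the measured compounds shown here, only one measured step bears on this change: the exchange of a 3-nitrophenyl for a thiophen-3-yl, a 4.6-fold lower number from compound 1 to compound 2 (0.66 log units; beyond the scatter), a modest step. The reverse direction, leaving the thiophen-3-yl for an aryl group again, is expected to move the number back upward by a comparable amount. For the measured compounds named here, compound 3 shows that a further aryl on the phenyl ring lies beyond the reach of the assay, but no step to compound 3 is available, so it only frames the upper possibility. The expected step is therefore an 8.1-fold higher number from compound 2 to compound 4 (0.91 log units; beyond the scatter), a modest rise. For compound 4 the estimate in this assay is 30 nM, expected between 8 nM and 150 nM.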

Compound 4, half-maximal inhibitory concentration: 150 nM
Beside the measured number, compound 4's estimate is 5.0-fold (0.70 log units) below it; measured number inside the range.
By their numbers in this assay, from the lowest: compound 2; then compound 1; then compound 4. At a limit, above all of these: compound 3.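

In this assay, among the compounds shown here, exchanging the thiophen-3-yl for 4-bromophenyl at the carbon next to the ring sulfur gives a 41-fold higher number from compound 2 to compound 4 (1.61 log units; beyond the scatter), a large step that shows this position discriminates far more sharply among aryl groups than the one earlier step suggested. Phenyl groups also differ clearly among themselves here: an 8.8-fold higher number from compound 1 to compound 4 (0.95 log units; beyond the scatter), a modest step that places the 4-bromophenyl compound above the 3-nitrophenyl compound. Compound 3 stands at a limit and not a number, and bromo in place of its outer phenyl gives an at least 66-fold lower number from compound 3 to compound 4 (1.82 log units; beyond the scatter), a large step that brings the series back to a measurable value: the limit of > 10000 nM in this assay, at which 1 of the 4 values shown sits.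

The compounds shown do not separate the effect of leaving the five-membered ring from that of the bromo itself, a question that a plain phenyl at this carbon would address. How a 4-fluorophenyl, a 4-methylphenyl or a furan-3-yl would read in this assay also remains open, so the compounds shown do not tell how far the rise follows the size of the group.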